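Triazole for Pyrimidine on a Thiazolylidene Hydrazide Core

The source may hold more compounds than are shown below. What is called first, only, known or untested is meant among the compounds shown, and "the series" means these compounds.

Compound 2 `O=C(CSc1ncccn1)N/N=c1/scc(-c2ccc(Br)cc2)n1-c1ccccc1` gives 273 ug/mL in an ADME assay on NIH3T3 cells (Mus musculus) for cytotoxicity, read by MTT assay, with a stated time of 24 h; a lower number here means a stronger inhibitor, a higher number a weaker inhibitor. Compound 1 `Cn1cnnc1SCC(=O)N/N=c1/scc(-c2ccc(Br)cc2)n1-c1ccccc1` carries 4-methyl-4H-1,2,4-triazol-3-yl in place of pyrimidin-2-yl on a sulfur; in this assay compound 1 gives 58.3 ug/mL, a step of a 4.7-fold lower number from compound 2 to compound 1 (0.67 log units; beyond the scatter). Compound 3 `COc1ccc(-c2cs/c(=N/NC(=O)CSc3ncccn3)n2-c2ccccc2)cc1` differs from compound 2 by methoxy in place of bromo on an aromatic carbon, and in this assay compound 3 gives 450 ug/mL, a step of a 1.6-fold higher number from compound 2 to compound 3 (0.22 log units; within the scatter). Compound 4 `COc1ccc(-c2cs/c(=N/NC(=O)CSc3nncn3C)n2-c2ccccc2)cc1` has not been measured. It differs from compound 3 by 4-methyl-4H-1,2,4-triazol-3-yl in place of pyrimidin-2-yl on a sulfur, the same change that separates compound 2 from compound 1, made on a core that differs by methoxy in place of bromo on an aromatic carbon. The step from compound 3 to compound 4 in this assay is expected to be a 4.5-fold lower number from compound 3 to compound 4 (0.65 log units; beyond the scatter). That expectation rests on the earlier step of a 4.7-fold lower number from compound 2 to compound 1 (0.67 log units; beyond the scatter). Compound 4 is estimated at 100 ug/mL in this assay.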

Compound 4, half-maximal inhibitory concentration: 167 ug/mL
For compound 4 the middle estimate is 1.7-fold (0.22 log units) below the measured one; the range from low to high includes it.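

In this assay, 4-methyl-4H-1,2,4-triazol-3-yl in place of pyrimidin-2-yl on a sulfur again lowers the number, with a step of a 2.7-fold lower number from compound 3 to compound 4 (0.43 log units; beyond the scatter), and the two steps for this change do not differ: the same change on two cores in this assay, a 4.7-fold lower number (0.67 log units; beyond the scatter) from compound 2 to compound 1 and a 2.7-fold lower number (0.43 log units; beyond the scatter) from compound 3 to compound 4, 1.7-fold (0.24 log units) apart, within the scatter of two such steps. Methoxy in place of bromo on an aromatic carbon gives a step of a 2.9-fold higher number from compound 1 to compound 4 (0.46 log units; beyond the scatter), and this change likewise does not differ from its earlier step: the same change on two cores in this assay, a 1.6-fold higher number (0.22 log units; within the scatter) from compound 2 to compound 3 and a 2.9-fold higher number (0.46 log units; beyond the scatter) from compound 1 to compound 4, 1.7-fold (0.24 log units) apart, within the scatter of two such steps. The change therefore carried across the two cores shown here, but a single pair of cores does not show that it would carry to any other core in the series.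

The compounds shown leave open how the step would run with a chloro group or an amine in place of bromo. They also leave open what a carboxylic acid would give in place of either sulfur-bound ring.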